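This account rests on a few compounds, and the source may have more. Where it says the series, first, only, none or still open, it means among the compounds named here.

Compound 1, `O=C(Nc1cc(-c2ccccc2)nn1-c1ccccc1)c1ccc(C(F)(F)F)cc1`, gives 38 nM in a functional assay on cells for positive allosteric modulation of metabotropic glutamate receptor 5 (Rattus norvegicus), read by calcium flux; a lower number here means that less compound is needed, a higher number that more compound is needed for the effect.
Compound 2, `COc1cc(OC)cc(C(=O)Nc2cc(-c3ccccc3)nn2-c2ccccc2)c1`, gives 2040 nM in this assay.
Compound 3, `O=C(Nc1cc(-c2ccccc2)nn1-c1ccccc1)c1ccc(Cl)c(Cl)c1`, gives 13 nM in this assay.

Compound 3 holds the lowest number of the three in this assay: the nearest is compound 1 (a 2.9-fold lower number from compound 1 to compound 3 (0.47 log units; beyond the scatter)), the furthest is compound 2 (a 160-fold lower number from compound 2 to compound 3 (2.20 log units; beyond the scatter)). Compound 4, `O=C(Nc1cc(-c2ccccc2)nn1-c1ccccc1)C1CCCC1`, differs from compound 3 by cyclopentyl in place of 3,4-dichlorophenyl on a carbonyl carbon.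

Among the measured compounds shown here, no measured step exchanges an aromatic ring for a non-aromatic one at this position; all three compared steps swap one substituted phenyl for another. They do show that the group on the carbonyl carbon sets the read-out strongly: a 54-fold higher number from compound 1 to compound 2 (1.73 log units; beyond the scatter) and a 160-fold lower number from compound 2 to compound 3 (2.20 log units; beyond the scatter) are large, a 2.9-fold lower number from compound 1 to compound 3 (0.47 log units; beyond the scatter) modest. For the measured compounds named here, with the aromatic ring removed in compound 4 and no close precedent, a sizable rise in this assay is expected rather than no change, though with wide uncertainty. Compound 4 is therefore estimated at 500 nM, range 80 nM to 5000 nM, which means an expected step of a 38-fold higher number from compound 3 to compound 4 (1.59 log units; beyond the scatter).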

Compound 4, half-maximal effective concentration: 3410 nM
Estimate against measurement, compound 4: 6.8-fold (0.83 log units) below; measured number inside the range.
By their numbers in this assay, from the lowest: compound 3; then compound 1; then compounds 2 and 4 (each within the scatter of the next).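

Cyclopentyl, the first non-aromatic group on this carbonyl carbon, gives large steps in this assay against both the 3,4-dichlorophenyl and the 4-(trifluoromethyl)phenyl groups: a 260-fold higher number from compound 3 to compound 4 (2.42 log units; beyond the scatter) and a 90-fold higher number from compound 1 to compound 4 (1.95 log units; beyond the scatter). Against 3,5-dimethoxyphenyl the same exchange gives a 1.7-fold higher number from compound 2 to compound 4 (0.22 log units; within the scatter), so a phenyl ring at this position does not by itself secure a low number: compound 2 carries one, compound 4 carries none, and the two cannot be told apart here. Nothing among the data shown explains these steps.

Going by these compounds, whether the low numbers of compound 1 and compound 3 depend on the aromatic ring, on its substituents or on both stays open, with a single non-aromatic group and three substituted phenyls to go on. Unsubstituted phenyl, 4-chlorophenyl or cyclohexyl on the carbonyl carbon would help separate these readings.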